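Cyclopentyl(methyl)amino in place of hydrogen on a purine-like core

The source may hold more compounds than are shown below. What is called first, only, known or untested is meant among the compounds shown, and "the series" means these compounds.

This account follows one unmeasured change within a small set of anticonvulsant compounds. The first member, compound 1 `C[C@H](c1ccccc1)n1cnc2c(N(C)C)ncnc21`, was tested in a functional assay on the whole organism for inhibition, with Rattus norvegicus as the target, in the maximal electroshock model, at a dose of 25 mg/kg by the intraperitoneal route (on this read-out higher numbers stand for more inhibition at the one dose given (going by the name of the read-out) and lower numbers for less inhibition), where compound 1 gives 33%. The second member, compound 2 `c1ccc(Cn2cnc3cncnc32)cc1`, was tested in the same setting, and in this assay compound 2 gives 33%. Compound 2 therefore stands level with compound 1 at the digits shown, the two readings lying within the usual scatter of one another, so no order between them can be claimed.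

The step of interest leads from compound 2 to compound 3 `CN(c1ncnc2c1ncn2Cc1ccccc1)C1CCCC1`. The structural change is cyclopentyl(methyl)amino in place of hydrogen on an aromatic carbon. Among the measured compounds shown here, no measured pair in this set shows such a step, so its size cannot be read off directly. Since compound 1, carrying a dimethylamino group on its core, gives 33%, and compound 2 gives 33%, no step beyond the scatter is expected from this change, and compound 3 is expected to show a number 2 percentage points higher from compound 2 to compound 3 (within the scatter) in this assay. The estimate for compound 3 is 35%, within a range from 15% to 60%.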

Compound 3, a percentage reported as inhibition, in the whole organism at one dose (the size of the read-out at that dose, not a potency): 17%
For compound 3 the middle estimate is 18 percentage points above the measured one, within the range that was stated.
By their numbers in this assay, from the lowest: compound 3; then compounds 1 and 2 (each within the scatter of the next).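

Cyclopentyl(methyl)amino in place of hydrogen on this aromatic carbon, next to the ring nitrogen, goes with a number 16 percentage points lower from compound 2 to compound 3 (beyond the scatter) in this assay. Among the compounds shown here, the earlier compounds formed no pair differing in one place, so this is the first reading of a change at this position, and it shows that the position is not indifferent to what it carries, at least for this group. Nothing at hand bears on what lies behind the step.

From the compounds shown here alone, whether the step belongs to the whole cyclopentyl(methyl)amino group or to the five-membered ring alone stays open, as does whether a plain amino group or a morpholine ring on the same carbon of compound 2 would move the reading as far, less far or the other way. The reading also comes from a single dose, so it leaves open how the change would look across other doses, and a single step cannot show whether larger groups at this position generally go with less inhibition.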